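Pyridin-3-yl to pyridin-4-yl in the sulfonyl series

This account rests on a few compounds, and the source may have more. Where it says the series, first, only, none or still open, it means among the compounds named here.

In a functional assay on SMMC-7721 cells (Homo sapiens) for cytotoxicity, read by MTT assay, with a stated time of 24 h (a higher number here means a weaker inhibitor, a lower number a stronger inhibitor), compound 1 (`CN1C/C(=C\c2cccnc2)C(=O)/C(=C/c2ccccc2C(F)(F)F)C1`) gives 3900 nM and compound 2 (`O=C1/C(=C/c2cccnc2)CN(S(=O)(=O)c2ccc([N+](=O)[O-])cc2)C/C1=C\c1ccccc1C(F)(F)F`) gives 15900 nM as the higher of the two numbers, so compound 2 is the weaker inhibitor of the pair. Going by the values given here, the single measured step, a 4.1-fold higher number from compound 1 to compound 2 (0.61 log units; beyond the scatter) for (4-nitrophenyl)sulfonyl in place of methyl on an amine nitrogen in a ring, is modest and lies beyond the scatter. Compound 3 (`O=C1/C(=C/c2ccncc2)CN(S(=O)(=O)c2ccc([N+](=O)[O-])cc2)C/C1=C\c1ccccc1C(F)(F)F`) differs from compound 2 thus: pyridin-4-yl in place of pyridin-3-yl on a double-bonded chain carbon bound to a double-bonded ring carbon with pyridin-4-yl in place of pyridin-3-yl on a double-bonded chain carbon bound to a double-bonded ring carbon. Among the compounds with values here, the measured step lies at a different place, so no measured step speaks to this change directly. No step beyond the scatter is therefore expected in this assay and no direction is favoured. The estimated step is a 1.2-fold lower number from compound 2 to compound 3 (0.09 log units; within the scatter) at the middle of the range. For compound 3 the estimated value is 13000 nM with a range from 5500 nM to 30000 nM as the expected span.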

Compound 3, half-maximal inhibitory concentration: > 20000 nM
Compound 3: a limit, no number; the forecaster's own chance of this, stated with the estimate: 3%; middle value at least 1.5-fold (0.18 log units) away from the limit.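

Going by these compounds alone, the earlier pair spoke only to the group on the ring amine nitrogen, whereas the new step, an at least 1.2-fold higher number from compound 2 to compound 3 (0.09 log units; that floor lies within the scatter), gives the first reading for pyridin-4-yl in place of pyridin-3-yl on a double-bonded chain carbon bound to a double-bonded ring carbon. In this assay compound 3 gives > 20000 nM, which is a limit and not a number. The step is therefore only a floor, so the change cannot be sized and no loss beyond the scatter can be claimed, and the reading sits at the top of the range: the limit of > 20000 nM in this assay, at which 1 of the 3 values shown sits.

Going by these compounds, whether the same change would read differently with methyl on the ring amine nitrogen stays open. Also open, on these data alone, is what pyridin-2-yl, or a phenyl ring carrying an amine, would give at this place.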